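Adding a Methoxy Group to Compound 1

The source may hold more compounds than are shown below. What is called first, only, known or untested is meant among the compounds shown, and "the series" means these compounds.

Compound 1 `COc1cc(CNC(=O)/C=C/c2ccccc2)ccc1O` gives 3660 nM in a functional assay on SH-SY5Y cells (Homo sapiens) for cytotoxicity, read by MTT assay, with stated times of 24 h and 4 h (on this read-out lower numbers stand for an effect already at smaller amounts and higher numbers for an effect only at larger amounts of compound), the starting point for this comparison. Compound 2 `COc1cc(CNC(=O)/C=C/c2ccccc2)ccc1OCc1nc(C)c(C)nc1C` carries (3,5,6-trimethylpyrazin-2-yl)methyl in place of hydrogen on an oxygen on an aromatic ring and gives 7310 nM. That change amounts to a 2.0-fold higher number from compound 1 to compound 2 (0.30 log units; within the scatter), so it separates the two compounds by no more than ordinary measurement variation. Compound 3 `COc1cc(CNC(=O)/C=C/c2ccccc2O)ccc1O` has hydroxy in place of hydrogen on an aromatic carbon and gives 9760 nM. This second change is a 2.7-fold higher number from compound 1 to compound 3 (0.43 log units; beyond the scatter).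

Compound 4 `COc1cccc(/C=C/C(=O)NCc2ccc(O)c(OC)c2)c1` has methoxy in place of hydrogen on an aromatic carbon, meta to a large group: methoxy in place of hydrogen on an aromatic carbon. The hydroxy change is the nearest guide, as it also replaces hydrogen on an aromatic carbon, but it is a single example with a different group. A modest rise is therefore expected, possibly not exceeding the scatter. The estimated change is a 1.6-fold higher number from compound 1 to compound 4 (0.21 log units; within the scatter). For compound 4, the expected value is 6000 nM, with an estimated range from 2500 nM to 14000 nM.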

Compound 4, half-maximal effective concentration: 5240 nM
Compound 4: the middle estimate sits 1.1-fold (0.06 log units) above what was measured, and the stated range covers the measured number.
By their numbers in this assay, from the lowest: compounds 1, 4, 2 and 3 (each within the scatter of the next, the first and the last beyond it).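

In this assay, methoxy on an aromatic carbon of the six-membered ring, meta to a large group, gives a 1.4-fold higher number from compound 1 to compound 4 (0.16 log units; within the scatter), so compound 4 cannot be told apart from compound 1 on this read-out. The earlier hydroxy change, a 2.7-fold higher number from compound 1 to compound 3 (0.43 log units; beyond the scatter), went beyond the scatter, so the two replacements of hydrogen on an aromatic carbon do not have the same standing: one clears ordinary measurement variation and the other does not. No measurement at hand explains this contrast between methoxy and hydroxy.

On these data alone, with only these two examples, it remains open whether the contrast follows the group itself or its place on the ring. An amine or a carboxylic acid at this same carbon would test how far the result holds for other groups.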